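This account rests on a few compounds, and the source may have more. Where it says the series, first, only, none or still open, it means among the compounds named here.

In a functional assay on ACHN cells (Homo sapiens) for inhibition, read by colorimetric assay and sulforhodamine B assay, with a stated time of 48 h (a lower number here means a stronger inhibitor of growth, a higher number a weaker inhibitor of growth), compound 1 `CCCCCCCCCCCC[C@@H](O)[C@H]1CC[C@H]([C@H](O)CCCCCCCCCCNC(=O)c2cccs2)O1` reads 2570 nM on its thiophen-2-yl amide, and compound 2 `CCCCCCCCCCCC[C@@H](O)[C@H]1CC[C@H]([C@H](O)CCCCCCCCCCNC(=O)c2ccoc2)O1` reads 100000 nM on its furan-3-yl amide. Compound 3 `CCCCCCCCCCCC[C@@H](O)[C@H]1CC[C@H]([C@H](O)CCCCCCCCCCNC(=O)c2cncs2)O1` reads 100000 nM and so shares the highest number of the three, showing no change at the digits printed from compound 2 to compound 3 (within the scatter) and also a 39-fold higher number from compound 1 to compound 3 (1.59 log units; beyond the scatter) in this small set. Compound 4 `CCCCCCCCCCCC[C@@H](O)[C@H]1CC[C@H]([C@H](O)CCCCCCCCCCNC(=O)c2ccnn2C)O1` brings one change on the carbonyl carbon of the amide: 1-methyl-1H-pyrazol-5-yl in place of 1,3-thiazol-5-yl on a carbonyl carbon in all. Compound 1 alone stands apart, with a 39-fold higher number from compound 1 to compound 2 (1.59 log units; beyond the scatter) at the same place, so 1-methyl-1H-pyrazol-5-yl in place of 1,3-thiazol-5-yl is expected to give no step beyond the scatter in this assay here. The expected outcome is a 1.7-fold lower number from compound 3 to compound 4 (0.22 log units; within the scatter) in this estimate. Compound 4 is estimated at 60000 nM with an expected span from 5000 nM to 100000 nM around that figure.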

Compound 4, concentration for 50% growth inhibition: 24000 nM
The estimate for compound 4 lay 2.5-fold (0.40 log units) above the measured number; low and high end bracket the measured number.
By their numbers in this assay, from the lowest: compound 1; then compound 4; then compounds 2 and 3 (each within the scatter of the next).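

In this assay the results give a 4.2-fold lower number from compound 3 to compound 4 (0.62 log units; beyond the scatter) and a 4.2-fold lower number from compound 2 to compound 4 (0.62 log units; beyond the scatter) so replacing thiophen-2-yl on this carbonyl carbon does not always lead to the same high number. 1,3-Thiazol-5-yl and 1-methyl-1H-pyrazol-5-yl have the same counts of ring hetero atoms and hydrogen-bond acceptors but still separate, while the result of a 9.3-fold higher number from compound 1 to compound 4 (0.97 log units; beyond the scatter) leaves thiophen-2-yl with the lower number. No evidence here accounts for these differences. On these data alone, whether the ring methyl matters remains open, as does the outcome with a phenyl ring or a pyridin-3-yl group on this carbonyl carbon.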